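Extending the side chain of an enyne ester pair

The source may hold more compounds than are shown below. What is called first, only, known or untested is meant among the compounds shown, and "the series" means these compounds.

Compound 2 `COC(=O)C#CC(CC(C)C)O/C=C/C(=O)OC` carries a branched saturated chain on the carbon that joins the triple bond and the vinyl ether oxygen. Going by the values given here, in a functional assay on SW1573 cells (Homo sapiens) for antiproliferative activity, read by sulforhodamine B assay, with a stated time of 48 h (on this read-out higher numbers stand for weaker inhibition of growth and lower numbers for stronger inhibition of growth), compound 2 gives 380 nM, the highest of the two numbers measured so far. Its nearest neighbour is compound 1 `CCCC(C#CC(=O)OC)O/C=C/C(=O)OC`, which in this assay gives 320 nM; the two differ by a 1.2-fold higher number from compound 1 to compound 2 (0.07 log units; within the scatter), so the pair cannot be ranked. Compound 3 `COC(=O)C#CC(C[C@@H](C)CCC=C(C)C)O/C=C/C(=O)OC` has not yet been measured. It differs from compound 2 in one place: 3-methylbut-2-en-1-yl in place of hydrogen on a saturated chain carbon, four bonds along the chain from an oxygen on an unsaturated carbon and a triple-bonded carbon. Among the compounds with values here, the only step measured so far lengthened the same chain by a single methyl group and stayed within the scatter, so there is no sign that growth on this chain shifts the number. The new group is larger, and such a change is expected to leave the number roughly where it is, an estimated step of a 1.1-fold higher number from compound 2 to compound 3 (0.02 log units; within the scatter). For compound 3 the expected value in this assay is 400 nM, within the range 150 nM to 1100 nM.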

Compound 3, concentration for 50% growth inhibition: 2200 nM
Beside the measured number, compound 3's estimate is 5.5-fold (0.74 log units) below it; measured number outside the range, above it.
By their numbers in this assay, from the lowest: compounds 1 and 2 (each within the scatter of the next); then compound 3.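

In this assay this chain does respond to growth: with 3-methylbut-2-en-1-yl in place of hydrogen there is a 5.8-fold higher number from compound 2 to compound 3 (0.76 log units; beyond the scatter) and so weaker inhibition of growth, whereas the single added methyl of the earlier step stayed within the scatter. Measured from the shorter chain, 4-methylpent-3-en-1-yl in place of hydrogen gives a 6.9-fold higher number from compound 1 to compound 3 (0.84 log units; beyond the scatter) and points the same way, so a small addition is tolerated here but this larger one is not. The data offer no measured explanation for this loss.

Only one large addition is shown, so it remains open whether the loss follows the chain's length, its double bond or its branching. A longer straight saturated chain, or an amine in place of the 3-methylbut-2-en-1-yl group, would help tell these apart.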